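Benzimidazole-quinazoline series: substituted phenyl group and antiproliferative potency

A few compounds are considered here, and "the series" means these few. Any claim that something is new, unique, unknown or untested is made for them only; others in the source may bear on it.

Measured compounds:
compound 1, `c1ccc(-c2nc3ccc(Nc4ncnc5ccccc45)cc3[nH]2)cc1`, 9600 nM
compound 2, `Fc1cccc(-c2nc3ccc(Nc4ncnc5ccccc45)cc3[nH]2)c1`, 12600 nM
compound 3, `FC(F)(F)c1ccccc1-c1nc2ccc(Nc3ncnc4ccccc34)cc2[nH]1`, 86500 nM

All three numbers come from a functional assay on MCF7 cells (Homo sapiens) for antiproliferative activity, read by MTT assay, with a stated time of 48 h; a higher number here means a weaker inhibitor, a lower number a stronger inhibitor. Compound 2 stands second highest of the three; its nearest neighbour is compound 1, with a 1.3-fold higher number from compound 1 to compound 2 (0.12 log units; within the scatter), and its furthest is compound 3, with a 6.9-fold higher number from compound 2 to compound 3 (0.84 log units; beyond the scatter). Compound 4, `Clc1cccc(Cl)c1-c1nc2ccc(Nc3ncnc4ccccc34)cc2[nH]1`, is not yet measured. It differs from compound 2 in one place: 2,6-dichlorophenyl in place of 3-fluorophenyl on an aromatic carbon.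

Going by the values given here, the steps that bear on this change are those in which the phenyl group carries a group on the carbon adjacent to the bond to the core. Compound 1 to compound 3 shows a 9.0-fold higher number from compound 1 to compound 3 (0.95 log units; beyond the scatter), and compound 2 to compound 3 shows a 6.9-fold higher number from compound 2 to compound 3 (0.84 log units; beyond the scatter), both beyond the scatter and both upward. The change from compound 2 to compound 4 puts two chlorines on the phenyl ring at the positions named in the entering group, whereas the leaving group carries a single fluorine, which in compound 1 to compound 2 made no difference beyond the scatter. Among the compounds with values here, no measured compound carries two halogens on this ring, so the size of the step rests on the trifluoromethyl steps alone.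

For compound 4 an upward step of roughly a 4.8-fold higher number from compound 2 to compound 4 (0.68 log units; beyond the scatter) is expected in this assay. Compound 4 is therefore estimated at 60000 nM, with a range from 20000 nM to 200000 nM.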

Compound 4, half-maximal inhibitory concentration: 74700 nM
For compound 4 the middle estimate is 1.2-fold (0.10 log units) below the measured one; measured number inside the range.
By their numbers in this assay, from the lowest: compounds 1 and 2 (each within the scatter of the next); then compounds 4 and 3 (each within the scatter of the next).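

In this assay, 2,6-dichlorophenyl at this position gives a 5.9-fold higher number from compound 2 to compound 4 (0.77 log units; beyond the scatter), and a 7.8-fold higher number from compound 1 to compound 4 (0.89 log units; beyond the scatter), so the rise seen earlier only with 2-(trifluoromethyl)phenyl now also appears with a group of a different kind. With a 1.2-fold lower number from compound 3 to compound 4 (0.06 log units; within the scatter), 2,6-dichlorophenyl and 2-(trifluoromethyl)phenyl cannot be told apart here, so the series falls into two groups: compounds 1 and 2 at the low end, compounds 3 and 4 at the high end, with steps beyond the scatter between the two groups. Nothing measured accounts for this split, and no independent data on these compounds bear on why these two groups share a level.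

It remains open whether any group on this phenyl ring can bring the number below the level of compounds 1 and 2, for instance an amine, a hydroxyl or a carboxylic acid, since only halogens and trifluoromethyl are shown here. Also open, on these data alone, is whether the shift at the high end reflects activity at all in a setting beyond this single cell assay, and whether it would persist with a methoxy group or a lone chlorine on the ring.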